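This account rests on a few compounds, and the source may have more. Where it says the series, first, only, none or still open, it means among the compounds named here.

Measured so far:

Compound 1 `Cn1cc(C2=C(c3nn(CCCn4cncn4)c4ncccc34)C(=O)NC2=O)c2ccccc21` — in a functional assay on A549 cells (Homo sapiens) for antiproliferative activity, read by MTT assay, with a stated time of 48 h (a higher number here means a weaker inhibitor, a lower number a stronger inhibitor), compound 1 gives > 100000 nM, which is a limit of the assay and not a number.
Compound 2 `Cn1cc(C2=C(c3nn(CCCn4cncn4)c4ncccc34)C(=O)N(c3ccccc3)C2=O)c2ccccc21` — compound 2 gives > 100000 nM, again a limit and not a number.
Among the compounds with values here, compound 3 `CN(C)CCCn1nc(C2=C(c3cn(C)c4ccccc34)C(=O)N(c3ccccc3)C2=O)c2cccnc21` — compound 3 gives 13000 nM, the only number among the three.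

Compound 4 `CN(C)CCCn1nc(C2=C(c3cn(C)c4ccccc34)C(=O)NC2=O)c2cccnc21` has not yet been measured. It differs from compound 3 by hydrogen in place of phenyl on an amide-type nitrogen in a ring. The same change occurs once more among the measured compounds, from compound 2 to compound 1, (hydrogen in place of phenyl on an amide-type nitrogen in a ring), where its step in this assay is a step that the two limits leave unreadable from compound 2 to compound 1 because both of those compounds sit at the limit of > 100000 nM in this assay, at which 2 of the 3 values shown sit. The surroundings of the place are described in identical words, so this is the same change, not merely the same kind. The two cores differ by dimethylamino in place of 1H-1,2,4-triazol-1-yl on a saturated chain carbon, three bonds along the chain from an aromatic nitrogen, and that step is an at least 7.6-fold lower number from compound 2 to compound 3 (0.88 log units; beyond the scatter).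

The one parallel step therefore offers no readable size, and nothing else shown speaks to what removing the phenyl does. The step from compound 3 to compound 4 is expected to be a 1.1-fold higher number from compound 3 to compound 4 (0.03 log units; within the scatter), small enough to fall inside the usual scatter. This rests on compound 3, whose value is 13000 nM, and on the unreadable step that the two limits leave unreadable from compound 2 to compound 1. Compound 4 is accordingly estimated at 14000 nM, with a range from 5000 nM to 45000 nM.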

Compound 4, half-maximal inhibitory concentration: > 100000 nM
Compound 4 ended at the assay's limit (the forecaster's own chance of this, stated with the estimate: 15%); middle value at least 7.1-fold (0.85 log units) away from the limit.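

In this assay, putting hydrogen in place of phenyl on the amide-type nitrogen in the ring of compound 3 gives an at least 7.6-fold higher number from compound 3 to compound 4 (0.88 log units; beyond the scatter), so on this core the phenyl is tied to the only measurable activity among the compounds shown. The value of compound 4, > 100000 nM, is a limit of the assay and not a number, so the true size of this step may be larger than printed. Whether the change behaves the same way on the core of compound 1 cannot be said, because the steps from compound 2 to compound 1 and from compound 1 to compound 4 cannot be read, with both ends of each step sitting at one value: the limit of > 100000 nM in this assay, at which 3 of the 4 values shown sit.

The compounds shown leave open whether a smaller group on that nitrogen, such as methyl or benzyl, would keep the value that compound 3 gives, 13000 nM. They also leave open what a different amine on the chain, such as morpholine, or a longer chain would do.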